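Oxan-4-yl for cyclohexyl on the urea nitrogen of compound 3

The compounds below may be only part of what the source reports. "The series", "measured", "known", "first", "only" and "open" are said of these compounds alone.

Measured compounds:
compound 1 `COc1nc(C)cc(SC)c1NC(=O)N(Cc1ccc(Oc2ccc(F)cc2)cc1)C1CCCCCC1` – 29 nM
compound 2 `Cc1cc(C)c(NC(=O)N(Cc2ccc(Oc3ccc(F)cc3)cc2)C2CCCCCC2)c(C)n1` – 62 nM
compound 3 `CSc1cc(C)nc(SC)c1NC(=O)N(Cc1ccc(Oc2ccc(F)cc2)cc1)C1CCCCC1` – 23 nM

In an assay for inhibition of acyl-CoA:cholesterol acyltransferase (Oryctolagus cuniculus), using microsomes (a lower number here means a stronger inhibitor, a higher number a weaker inhibitor), compound 3 gives the lowest number of the three, though its gap to compound 1 lies within the scatter, so the two cannot be ordered; only compound 2 sits clearly apart. Compound 1 and compound 3 differ in two places at once, so their values are taken as they stand without reading a step from them. Within the data shown here, the one single-point step available, a 2.1-fold higher number from compound 1 to compound 2 (0.33 log units; beyond the scatter), changes the aryl group on the urea nitrogen and is modest.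

Compound 4 `CSc1cc(C)nc(SC)c1NC(=O)N(Cc1ccc(Oc2ccc(F)cc2)cc1)C1CCOCC1` is not yet measured. It differs from compound 3 by oxan-4-yl in place of cyclohexyl on an amide-type nitrogen. Among the measured compounds shown here, no measured step touches this ring: the only step concerns the aryl side, and the ring on the urea nitrogen is otherwise varied only between compound 1 and compound 3, where a second change is present too. For the measured compounds named here, the expectation therefore rests on the general size of the one step seen, and a small shift in this assay, a 2.2-fold higher number from compound 3 to compound 4 (0.34 log units; beyond the scatter), is expected, its direction uncertain. Compound 4 is estimated at 50 nM, with a range of 20 nM to 150 nM.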

Compound 4, half-maximal inhibitory concentration: 46 nM
Compound 4: the middle estimate sits 1.1-fold (0.04 log units) above what was measured, within the range that was stated.
By their numbers in this assay, from the lowest: compounds 3, 1, 4 and 2 (each within the scatter of the next, the first and the last beyond it).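

In this assay, among these compounds, a 2.0-fold higher number from compound 3 to compound 4 (0.30 log units; within the scatter) comes with oxan-4-yl in place of cyclohexyl on the amide-type nitrogen, the first step that isolates the ring at this place, as the earlier ring variation came with a second change. With the rest of the structure held constant, a ring oxygen and its one hydrogen-bond acceptor enter at this place without a step that stands beyond the scatter, so this pair gives no firm separation of the two rings, although the step is as large as the scatter allows. No separate measurement bears on this result, so the data give no explanation for the size of the step.

The compounds shown leave open whether a piperidin-4-yl ring, with a nitrogen in place of the oxygen, or an open hexyl chain on this amide-type nitrogen would stay within the scatter of compound 3. They also leave open whether oxan-4-yl gives a comparable step alongside the aryl groups of compound 1 and compound 2, since it appears here only with the aryl group of compound 3.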